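Working Notes on an Antiproliferative Series, Compound 3 Pending

This account rests on a few compounds, and the source may have more. Where it says the series, first, only, none or still open, it means among the compounds named here.

Measured compounds:
compound 1, `Fc1ccc(-c2nss/c2=N\c2ccccc2)cc1`: 0%
compound 2, `c1ccc(/N=c2\ssnc2-c2ccco2)cc1`: 0%

In a functional assay on MDA-MB-231 cells (Homo sapiens) for antiproliferative activity, read by MTT assay, with a stated time of 72 h, tested at 10 uM (a higher number here means more inhibition at the concentration tested (going by the name of the read-out), a lower number less inhibition), compound 1 gives 0%. In this assay compound 2 gives 0%, level with compound 1 within the scatter. Compound 3, `Cc1nss/c1=N\c1ccccc1`, differs from compound 2 in one place: methyl in place of furan-2-yl on an aromatic carbon. Within the data shown here, no step between measured compounds is available, and compounds 1 and 2 show no difference beyond the scatter. The step is estimated as no change at the digits printed from compound 2 to compound 3 (within the scatter), expected to be none beyond the scatter, because compound 2 gives 0% with compound 1 at the same level. For compound 3 the expected value is 0%, with a range from 0% to 12%.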

Compound 3, a percentage reported as inhibition, at one concentration (the size of the read-out at that concentration, not a potency): 0%
The estimate for compound 3 equals the measured number at the digits printed; the range from low to high includes it.
By their numbers in this assay, from the lowest: compounds 1, 2 and 3 (each within the scatter of the next).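

In this assay, methyl in place of furan-2-yl on this aromatic carbon gives no change at the digits printed from compound 2 to compound 3 (within the scatter). Compounds 1 and 2 both carry an aromatic ring at this position, whereas compound 3 at 0% shows that a group with no ring gives the same reading. No available evidence bears on this result. From the compounds shown here alone, with all three compounds at the same reading, the series shows no inhibition that a change here could lower, so the importance of this position stays open. Going by these compounds, whether an amine or a carboxylic acid on this carbon would produce inhibition also remains open.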